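Adding a methoxy group to a pyrazole chalcone

A few compounds are considered here, and "the series" means these few. Any claim that something is new, unique, unknown or untested is made for them only; others in the source may bear on it.

Measured so far:
compound 1, `COc1cc(-c2cc(/C=C/C(=O)c3ccc(Cl)c(Cl)c3)[nH]n2)cc(OC)c1OC`: 10%
compound 2, `COc1ccc(-c2cc(/C=C/C(=O)c3cc(OC)c(OC)c(OC)c3)[nH]n2)cc1OC`: -72%

Both compounds were tested in a functional assay on COLO 205 cells (Homo sapiens) for cytotoxicity, read by sulforhodamine B assay, with a stated time of 48 h, tested at 10 uM; on this read-out higher numbers stand for a weaker effect at the one concentration tested and lower numbers for a stronger effect. Compound 2 gives -72%, the lowest of the two numbers, and on this read-out that means the stronger effect. Compound 1 gives 10%, a number far higher, well beyond the scatter of repeated measurements.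

Compound 3, `COc1cc(C(=O)/C=C/c2cc(-c3cc(OC)c(OC)c(OC)c3)n[nH]2)cc(OC)c1OC`, has not yet been measured. It differs from compound 2 in one place: methoxy in place of hydrogen on an aromatic carbon. The two compounds are otherwise identical.

Among the compounds with values here, no step between two measured compounds shows what this particular change does, since compound 1 and compound 2 differ in more than one place. The expectation therefore rests on compound 2 alone. A small step is expected in this assay, most likely within the scatter or slightly toward a weaker effect, with the step expected to be a number 12 percentage points higher from compound 2 to compound 3 (beyond the scatter). Compound 3 is estimated to give -60%, with a range from -95% to 5%.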

Compound 3, a percentage reported as activity, at one concentration (the size of the read-out at that concentration, not a potency): -100%
The estimate for compound 3 lay 40 percentage points above the measured number; measured number outside the range, below it.
By their numbers in this assay, from the lowest: compound 3; then compound 2; then compound 1.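

In this assay the hydrogen-to-methoxy change gives a number 28 percentage points lower from compound 2 to compound 3 (beyond the scatter) and so moves the result toward a stronger effect at the single concentration tested. The new methoxy group sits on a six-membered aromatic ring of carbon only, ortho to a methoxy group, meta to a second methoxy group and meta to a large group, and this position therefore accepts the added group without any loss of effect, something compound 1 and compound 2 could not show because they differ in more than one place. Nothing available here explains why the number moved in this direction.

The compounds shown leave open whether the stronger effect belongs to methoxy in particular or would also appear with another group on the same aromatic carbon, such as a hydroxyl, an amine, a fluorine atom or a longer ethoxy chain. They also leave open whether the same change would act similarly on a different background, such as the one carrying the chlorine atoms in compound 1, and how the compounds compare in potency, which a reading at one concentration cannot give.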